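The source may report more compounds than this note shows. Statements on the series, on what has been measured and on what is new or still open speak of the compounds shown alone.

Going by the values given here, compound 2, `Cc1c(Cc2ccccc2S(=O)(=O)N2CCOCC2)c2c(n1CC(=O)O)CCNC2=O`, stands at the higher of the two numbers recorded so far, with compound 1, `COc1cccc(S(=O)(=O)c2ccccc2Cc2c3c(n(CC(=O)O)c2C)CCNC3=O)c1`, as its only neighbour. In a functional assay on CHO.K1 cells for antagonist activity at prostaglandin D2 receptor 2 (Homo sapiens), read by GTPgammaS binding, with a stated time of 1 h (on this read-out higher numbers stand for weaker inhibition and lower numbers for stronger inhibition), compound 1 gives 12 nM, and compound 2 gives 22 nM; the step of a 1.8-fold higher number from compound 1 to compound 2 (0.26 log units; within the scatter) separates them. Compound 3, `Cc1c(Cc2ccccc2Cn2ccnn2)c2c(n1CC(=O)O)CCNC2=O`, carries a different substituent on the same aromatic carbon: (1H-1,2,3-triazol-1-yl)methyl in place of (morpholin-4-yl)sulfonyl on an aromatic carbon. Among the compounds with values here, only one measured step bears on this change, and it concerns the same position: a 1.8-fold higher number from compound 1 to compound 2 (0.26 log units; within the scatter), which exchanged one group on a sulfonyl sulfur for another while keeping the sulfonyl itself. Here the sulfonyl leaves altogether, so that step is only a loose guide. Because a 1.8-fold higher number from compound 1 to compound 2 (0.26 log units; within the scatter) stayed within the scatter, a small loss, expected as a 2.7-fold higher number from compound 2 to compound 3 (0.44 log units; beyond the scatter), seems the likelier outcome in this assay. Compound 3 is therefore estimated at 60 nM, within a range of 15 nM to 250 nM.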

Compound 3, half-maximal inhibitory concentration: 800 nM
For compound 3 the middle estimate is 13-fold (1.12 log units) below the measured one, outside the stated range (above it).
By their numbers in this assay, from the lowest: compounds 1 and 2 (each within the scatter of the next); then compound 3.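

In this assay the change costs far more than the earlier exchange on the sulfonyl sulfur suggested, with a 36-fold higher number from compound 2 to compound 3 (1.56 log units; beyond the scatter) and, against the other sulfonyl compound, a 67-fold higher number from compound 1 to compound 3 (1.82 log units; beyond the scatter) in the same direction. This aromatic carbon therefore accepts different groups on the sulfonyl sulfur with little change in the number, yet it does not accept (1H-1,2,3-triazol-1-yl)methyl in place of either sulfonyl group. Nothing available explains the size of this loss.

The sulfonyl group and the ring on it leave together in this step, so the compounds shown cannot separate their contributions. A (morpholin-4-yl)methyl group, which would keep the morpholine ring without the sulfonyl, or a (1H-pyrazol-1-yl)sulfonyl group, which would keep the sulfonyl with a five-membered aromatic ring, could each divide the loss between the two.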